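This account rests on a few compounds, and the source may have more. Where it says the series, first, only, none or still open, it means among the compounds named here.

Measured so far:
Compound 1 `Cn1cc(C2CC(c3ccccc3)=NN2C(=O)c2cccnc2)c2cc(Br)ccc21` in an ADME assay on HEK-293T cells (Homo sapiens) for cytotoxicity, read by MTT assay, with a stated time of 48 h (a lower number here means that less compound is tolerated, a higher number that more compound is tolerated), gives > 300000 nM, a limit of the assay.
Compound 2 `Cn1cc(C2CC(c3ccc(Br)cc3)=NN2C(=O)c2cccnc2)c2cc(Br)ccc21` in this assay gives > 300000 nM, a limit of the assay.
Compound 3 `COc1ccc(C2=NN(C(=O)c3cccnc3)C(c3cn(C)c4ccc(Br)cc34)C2)cc1` in this assay gives > 300000 nM, a limit of the assay.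

All three values sit at the limit of > 300000 nM in this assay, at which 3 of the 3 values shown sit. The change from compound 2 to compound 3, (methoxy in place of bromo on an aromatic carbon), gave a step that the two limits leave unreadable from compound 2 to compound 3. The cores of compound 2 and compound 1 differ by hydrogen in place of bromo on an aromatic carbon. Compound 4 `COc1ccc2c(c1)c(C1CC(c3ccccc3)=NN1C(=O)c1cccnc1)cn2C` is not yet measured; it differs from compound 1 by methoxy in place of bromo on an aromatic carbon, the same kind of change, but at a different place: on an aromatic carbon of a six-membered aromatic ring of carbon only, part of a fused or bridged system of two rings, meta to a fused ring and para to a fused ring, whereas the earlier change sat para to a large group. For compound 4 a step that the limit leaves unreadable from compound 1 to compound 4 is expected, resting on compound 2 and compound 3 and their step that the two limits leave unreadable from compound 2 to compound 3, which left both at the limit. Compound 4 is therefore estimated at 400000 nM, with a range of 150000 nM to 1500000 nM, most likely again reported only as a limit.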

Compound 4, half-maximal cytotoxic concentration: > 300000 nM
Compound 4: only a limit was reported; the forecaster's own chance of this, stated with the estimate: 85%; the middle value lies beyond the limit too.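

No step can be read between compound 1 and compound 4, since each is reported only as a limit: the limit of > 300000 nM in this assay, at which 4 of the 4 values shown sit.

The compounds shown leave open whether methoxy in place of bromo, or any other change in this series, shifts the tolerated concentration at all.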